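The source may hold more compounds than are shown below. What is called first, only, known or untested is meant among the compounds shown, and "the series" means these compounds.

Measured so far in an assay on HeLa cells for displacement of a labelled ligand from 5-hydroxytryptamine receptor 6 (Homo sapiens); on this read-out lower numbers stand for stronger inhibition and higher numbers for weaker inhibition:
compound 1 `CSc1nc2ccccn2c(=N)c1S(=O)(=O)c1ccc(OC(F)(F)F)cc1`: 420 nM
compound 2 `N=c1c(S(=O)(=O)c2ccccc2)c(NCCO)nc2ccccn12`: 42 nM
compound 3 `CSc1nc2ccc(F)cn2c(=N)c1S(=O)(=O)c1ccccc1`: 28 nM

Compound 3 has the lowest of the three numbers. Its nearest neighbour is compound 2, whose value lies within the usual scatter, so no order between these two can be claimed. Compound 1 stands far beyond the scatter from compound 3.

Compound 4 `CSc1nc2ccc(Cl)cn2c(=N)c1S(=O)(=O)c1ccccc1` has not yet been tested. It differs from compound 3 in one place: chloro in place of fluoro on an aromatic carbon. Among the measured compounds shown here, no measured pair shows this exchange, so the expectation rests on the change alone. A swap of one halogen for another of this kind is expected to move the number little, if at all, beyond the scatter. Compound 4 is therefore expected to give about 25 nM, with a range from 9 nM to 70 nM. That estimate means a step of a 1.1-fold lower number from compound 3 to compound 4 (0.05 log units; within the scatter), expected to remain within the scatter.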

Compound 4, half-maximal inhibitory concentration: 28 nM
Beside the measured number, compound 4's estimate is 1.1-fold (0.05 log units) below it; measured number inside the range.
By their numbers in this assay, from the lowest: compounds 3, 4 and 2 (each within the scatter of the next); then compound 1.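

In this assay, among the compounds shown here, chloro in place of fluoro on this aromatic carbon gives no change at the digits printed from compound 3 to compound 4 (within the scatter) and is the first exchange that can be read on its own. For the compounds shown here, the earlier compounds offered no pair differing in one place, so this is the first direct sign that this carbon takes either halogen with no visible shift in the number. No measurement shown explains why the two halogens read alike. Still open, going by these compounds, is whether an amine or a carboxylic acid on this carbon would leave the number equally unmoved.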